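A few compounds are considered here, and "the series" means these few. Any claim that something is new, unique, unknown or untested is made for them only; others in the source may bear on it.

In a functional assay on DLD-1 cells (Homo sapiens) for antiproliferative activity, read by CellTiter-Glo, with a stated time of 72 h (on this read-out higher numbers stand for weaker inhibition and lower numbers for stronger inhibition), compound 1 `Cc1cc(C)c(S(=O)(=O)N2CCC(N3CCC(c4ccccc4)CC3)CC2)c(C)c1` gives 865 nM, and compound 2 `Cc1cc(C)c(S(=O)(=O)N2CCC(N3CCC(CCO)CC3)CC2)c(C)c1` gives 19 nM. Among the compounds with values here, the single measured step, a 46-fold lower number from compound 1 to compound 2 (1.66 log units; beyond the scatter), was large and lowered the number. Among the two numbers so far, compound 2 stands lowest, with compound 1 as its only neighbour. Compound 3 `Cc1cc(C)c(S(=O)(=O)N2CCC(N3CCC(CCC#N)CC3)CC2)c(C)c1` differs from compound 2 by cyano in place of hydroxy on a saturated chain carbon, two bonds along the chain from a saturated ring carbon. Within the data shown here, no measured step bears directly on this change: the step from compound 1 to compound 2 exchanged a phenyl for the whole 2-hydroxyethyl chain, whereas here the chain is kept and only its terminal group is exchanged, so that step gives no guide to the size expected. In this assay the expected step is a 1.8-fold higher number from compound 2 to compound 3 (0.27 log units; within the scatter), a modest shift toward a higher number. Compound 3 is accordingly estimated at 35 nM, within a range from 10 nM to 120 nM.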

Compound 3, half-maximal inhibitory concentration: > 5000 nM
Compound 3 was reported as a limit; the forecaster's own chance of this, stated with the estimate: 2%; at least 140-fold (2.15 log units) between middle value and limit.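

In this assay, the end of the chain matters as much as the chain itself: with the chain kept, cyano in place of hydroxy gives an at least 260-fold higher number from compound 2 to compound 3 (2.42 log units; beyond the scatter). The 2-cyanoethyl group in place of phenyl on a saturated ring carbon gives an at least 5.7-fold higher number from compound 1 to compound 3 (0.76 log units; beyond the scatter), so the low number of the 2-hydroxyethyl compound does not extend to every chain of that length. The reading for compound 3 is a limit of the assay, not a number: the limit of > 5000 nM in this assay, at which 1 of the 3 values shown sits.

The hydroxy group counts one hydrogen-bond donor and the cyano group none, but these compounds cannot show whether that difference is what matters, since a methyl ether at the chain end would be needed to separate it. On these data alone, how an amine, a carboxylic acid or a longer chain ending in hydroxy would read at this place remains open.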